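The compounds below may be only part of what the source reports. "The series", "measured", "known", "first", "only" and "open" are said of these compounds alone.

Compound 3, `CC(C)c1c(C(=O)N2CCCC2c2ccccc2)nn(-c2ccc(F)cc2)c1OC[C@@H](O)C[C@@H](O)CC(=O)O`, stands highest among the three numbers in an assay on microsomes from liver for inhibition of 3-hydroxy-3-methylglutaryl-coenzyme A reductase (Rattus norvegicus) (on this read-out higher numbers stand for weaker inhibition and lower numbers for stronger inhibition), giving 14 nM. Compound 2, `CC(C)c1c(C(=O)N(C)Cc2cccc(F)c2)nn(-c2ccc(F)cc2)c1CC[C@@H](O)C[C@@H](O)CC(=O)O`, gives 4.1 nM, and compound 1, `CC(C)c1c(C(=O)N2CCC[C@H](c3ccccc3)C2)nn(-c2ccc(F)cc2)c1CC[C@@H](O)C[C@@H](O)CC(=O)O`, gives 2.1 nM; both lie below compound 3 by gaps beyond the scatter. Compound 4, `COc1ccccc1CNC(=O)c1nn(-c2ccc(F)cc2)c(OC[C@@H](O)C[C@@H](O)CC(=O)O)c1C(C)C`, is reached from compound 3 by one change: (2-methoxybenzyl)amino in place of 2-phenylpyrrolidin-1-yl on a carbonyl carbon.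

Among the measured compounds shown here, the one measured step that touches the same place is the exchange of amide substituents on the carbonyl carbon between compound 1 and compound 2, which gave a 2.0-fold higher number from compound 1 to compound 2 (0.29 log units; within the scatter). That step swapped a cyclic amine for an open benzylic one and stayed within the scatter, so the amide substituent appears tolerant of such variation in this assay. The change at hand is of the same kind, though it also replaces a group bearing no hydrogen-bond donor with one bearing one donor and one acceptor. Compound 4 is therefore expected to move little from compound 3, by about a 1.4-fold higher number from compound 3 to compound 4 (0.15 log units; within the scatter), a step not beyond the scatter. Compound 4 is estimated at 20 nM, within 6 nM to 60 nM.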

Compound 4, half-maximal inhibitory concentration: 22 nM
Estimate against measurement, compound 4: 1.1-fold (0.04 log units) below, within the range that was stated.
By their numbers in this assay, from the lowest: compounds 1 and 2 (each within the scatter of the next); then compounds 3 and 4 (each within the scatter of the next).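

In this assay the exchange gave a 1.6-fold higher number from compound 3 to compound 4 (0.20 log units; within the scatter) and so, on the core of compound 3, the carbonyl carbon carried either 2-phenylpyrrolidin-1-yl or (2-methoxybenzyl)amino with no difference beyond the scatter. Unlike the earlier step, this one brings in a hydrogen-bond donor and a hydrogen-bond acceptor, and it occurs on a different core, so the same insensitivity now appears in two separate pairs of compounds. No evidence is available that would explain this result.

As far as these compounds go, what a piperazine or a carboxylic acid on this carbonyl carbon would do remains open. The separate contribution of the chain on the core also stays unresolved, since compound 3 and compound 4 each differ from compound 1 and compound 2 in more than one place.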